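Methyl to ethyl among compounds known only by limits

The source may report more compounds than this note shows. Statements on the series, on what has been measured and on what is new or still open speak of the compounds shown alone.

In a functional assay on the whole organism for antagonist activity, with Mus musculus as the target (on this read-out lower numbers stand for an effect already at smaller amounts and higher numbers for an effect only at larger amounts of compound), compound 3 `Cn1c(-c2ccccc2F)nnc1[S+](C)[O-]` gives > 200 mg/kg, which is a limit of the assay and not a number. Compound 1 `Cn1c(-c2ccccc2)nnc1[S+](C)[O-]` gives > 100 mg/kg, also a limit. Compound 2 `CSc1nnc(-c2ccccc2Cl)n1C` gives > 50 mg/kg, again a limit. Among the compounds with values here, no compound here has yet reached a true half-maximal dose, and compound 3 therefore has no exact place in the order.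

Compound 4 `CC[S+]([O-])c1nnc(-c2ccccc2F)n1C` is built from compound 3 by one small change, methyl in place of hydrogen on a saturated chain carbon bound to a sulfur, which turns methyl into ethyl.

Within the data shown here, the only measured step is a step that the two limits leave unreadable from compound 1 to compound 3, with fluoro in place of hydrogen on an aromatic carbon. It lies at a different place and gives no size to carry over. The remaining guide for compound 3 is the limit of > 200 mg/kg in this assay, at which 1 of the 3 values shown sits.

With no readable step to build on, neither direction is favoured, and no shift beyond the scatter is expected in this assay. The expected change is a number no higher from compound 3 to compound 4 (the limit leaves the size open). A report of compound 4 as another limit would be the likeliest outcome. For compound 4 the estimated dose is 200 mg/kg. The expected range for compound 4 runs from 70 mg/kg to 500 mg/kg.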

Compound 4, dose for half-maximal effect: > 200 mg/kg
Compound 4: a limit, no number; the forecaster's own chance of this, stated with the estimate: 85%; the middle value lies on the limit itself.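

Within the data shown here, compound 3 and compound 4 are both known only by limits of the assay, so the change from methyl to ethyl gives no step that can be read, and the same holds for the earlier step from compound 1 to compound 3. The compounds shown leave open the dose at which any of them reaches a half-maximal effect, and whether either change shifts that dose.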